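Swapping chloro for trifluoromethyl on the urea aryl group

The compounds below may be only part of what the source reports. "The series", "measured", "known", "first", "only" and "open" are said of these compounds alone.

Compound 3, `O=C(Nc1cccc(-n2cc(-c3ccncc3)c(-c3ccc(Cl)c(O)c3)n2)c1)Nc1ccc(Cl)c(Cl)c1`, was tested in a functional assay on LOX IMVI cells (Homo sapiens) for inhibition, read by sulforhodamine B assay, with a stated time of 48 h (a lower number here means that less compound is tolerated, a higher number that more compound is tolerated), and gives 15000 nM. Among the numbers shown it stands highest; its nearest neighbour is compound 1, `COc1cc(-c2nn(-c3cccc(NC(=O)Nc4cc(C(F)(F)F)cc(C(F)(F)F)c4)c3)cc2-c2ccncc2)ccc1Cl`, which gives 2940 nM. Compound 2, `COc1cc(-c2nn(-c3cccc(NC(=O)Nc4ccc(Cl)c(Cl)c4)c3)cc2-c2ccncc2)ccc1Cl`, reaches only the assay limit of > 50000 nM in this assay. Within the data shown here, the one measured step that runs between compounds differing in a single place is an at least 3.3-fold lower number from compound 2 to compound 3 (0.52 log units; beyond the scatter), a change on an oxygen that is unlike the one considered here.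

Compound 4, `O=C(Nc1cccc(-n2cc(-c3ccncc3)c(-c3ccc(Cl)c(O)c3)n2)c1)Nc1ccc(Cl)c(C(F)(F)F)c1`, differs from compound 3 by trifluoromethyl in place of chloro on an aromatic carbon. Among the measured compounds shown here, no measured pair isolates this change; compound 1 carries trifluoromethyl groups and compound 2 chloro groups on the same ring, but they differ in more than one place. With so little to lean on, compound 4 is expected to give a modestly lower number than compound 3, a step of a 2.1-fold lower number from compound 3 to compound 4 (0.33 log units; beyond the scatter), and its value in this assay is estimated at 7000 nM, within 2000 nM to 25000 nM.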

Compound 4, concentration lethal to 50% of the cells: 2390 nM
For compound 4 the middle estimate is 2.9-fold (0.47 log units) above the measured one; the range from low to high includes it.
By their numbers in this assay, from the lowest: compounds 4 and 1 (each within the scatter of the next); then compound 3. At a limit, above all of these: compound 2.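

In this assay, among these compounds, this is the first pair that isolates the swap, and trifluoromethyl in place of chloro gives a 6.3-fold lower number from compound 3 to compound 4 (0.80 log units; beyond the scatter). Among the compounds shown here, compounds 1 and 2 could not show this, as they differ in more than one place, whereas here only one group changes, on an aromatic carbon ortho to a chloro group, and the rest of the molecule stays the same. The lower number of compound 4 can therefore be tied to this single swap, although nothing shown explains why the number moves.

One pair cannot show whether the swap would have a similar effect in compounds with methyl on the oxygen, as in compound 2. From the compounds shown here alone, how an amine or a carboxylic acid at this same position would compare with chloro and trifluoromethyl also remains open.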